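The source may report more compounds than this note shows. Statements on the series, on what has been measured and on what is new or still open speak of the compounds shown alone.

Measured compounds in a functional assay on MCF7 cells (Homo sapiens) for antiproliferative activity, read by MTT assay, with a stated time of 24 h; a lower number here means that less compound is needed, a higher number that more compound is needed for the effect:
compound 1 `CSc1ccc(/C(=N\OCCCCN2CCCCC2)c2cccc3ccccc23)cc1` gives 8000 nM
compound 2 `CSc1ccc(/C(=N\OCCCCN2CCCC2)c2cccc3ccccc23)cc1` gives > 50000 nM, a limit of the assay and not a number

Compound 2 therefore stands only at the edge of what this assay reports, (the limit of > 50000 nM in this assay, at which 1 of the 2 values shown sits). Among the measured compounds shown here, the single measured step, an at least 6.2-fold higher number from compound 1 to compound 2 (0.79 log units; beyond the scatter), shows that exchanging one saturated nitrogen ring for another at this position already moves the read-out beyond the scatter, and in the unfavourable direction for pyrrolidin-1-yl.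

Compound 3 `CCN(CCCCO/N=C(\c1ccc(SC)cc1)c1cccc2ccccc12)Cc1ccccc1` carries the change (benzyl(ethyl)amino in place of pyrrolidin-1-yl on a saturated chain carbon, four bonds along the chain from an oxygen). The measured step bears on the same place but runs from a six-membered ring to a five-membered one; the present change goes the other way in size, from the small ring to an open benzyl(ethyl)amino group, so the direction cannot be read straight off. Since the smaller amine gave the limit, a return toward a number is expected rather than a further loss, but with wide uncertainty. Compound 3 is expected in this assay at 25000 nM, within 6000 nM to 100000 nM. That estimate corresponds to an expected step of an at least 2.0-fold lower number from compound 2 to compound 3 (0.30 log units; that floor lies within the scatter).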

Compound 3, half-maximal effective concentration: > 50000 nM
Compound 3: only a limit was reported; the forecaster's own chance of this, stated with the estimate: 45%; middle value at least 2.0-fold (0.30 log units) from the limit.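

With benzyl(ethyl)amino in place of piperidin-1-yl, the read-out shows an at least 6.2-fold higher number from compound 1 to compound 3 (0.79 log units; beyond the scatter), so the loss at this position, on a saturated chain carbon, four bonds along the chain from an oxygen, is not confined to the pyrrolidin-1-yl ring of the earlier step. Compound 3 gives > 50000 nM in this assay, which is a limit of the assay and not a number, and the step from compound 2 joins two limits and cannot be read. Of the three amines at this position, only the piperidin-1-yl of compound 1 gives a number, and the other two share the same limit: the limit of > 50000 nM in this assay, at which 2 of the 3 values shown sit.

As far as these compounds go, how far compound 2 and compound 3 lie past that limit stays unknown, so no order can be set between pyrrolidin-1-yl and benzyl(ethyl)amino. Also open, from the compounds shown here alone, is whether the number of compound 1 belongs to piperidin-1-yl alone or extends to other amines at this position, such as morpholin-4-yl, 4-methylpiperazin-1-yl or dimethylamino, and whether a longer chain carrying piperidin-1-yl would move the read-out.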